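Amide substituent exchange: expectation for compound 3

The compounds below may be only part of what the source reports. "The series", "measured", "known", "first", "only" and "open" are said of these compounds alone.

Measured so far:
Compound 1, `CO[C@]1(C(=O)N2CC[C@](c3ccc(C(F)(C(F)(F)F)C(F)(F)F)cc3)(S(=O)(=O)c3ccc(F)cc3)C2)CC[C@H](C(=O)O)CC1`, gives 82% in an ADME assay on microsomes from liver (Homo sapiens) for metabolic stability, with a stated time of 10 min; a higher number here means that more of the compound is left, a lower number that less of the compound is left.
Compound 2, `COC[C@]1(C(=O)N2CC[C@](c3ccc(C(F)(C(F)(F)F)C(F)(F)F)cc3)(S(=O)(=O)c3ccc(F)cc3)C2)CC[C@H](C(=O)O)CC1`, gives 100% in this assay.

Compound 2 holds the highest of the two numbers in this assay; its nearest neighbour is compound 1, and the step of a number 18 percentage points higher from compound 1 to compound 2 (beyond the scatter) lies beyond the scatter. Among the measured compounds shown here, that step, methoxymethyl in place of methoxy on a saturated ring carbon, is the only measured step on the shared core.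

Compound 3, `O=C(C1CCS(=O)(=O)CC1)N1CC[C@](c2ccc(C(F)(C(F)(F)F)C(F)(F)F)cc2)(S(=O)(=O)c2ccc(F)cc2)C1`, is not yet measured. It differs from compound 2 as follows: 1,1-dioxothian-4-yl in place of 4-carboxy-1-(methoxymethyl)cyclohexyl on a carbonyl carbon. For the measured compounds named here, the one measured step concerns a group that is itself part of what leaves here, so it does not bear on this exchange; no measured pair speaks to the change, and the direction is open from the data. With compound 2 already giving the full amount remaining in this assay, the number can only hold or fall, and a modest fall is expected, a number 25 percentage points lower from compound 2 to compound 3 (beyond the scatter). For compound 3 the estimate in this assay is 75%, with a range from 45% to 100%.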

Compound 3, percent of the compound remaining: 93%
Beside the measured number, compound 3's estimate is 18 percentage points below it; measured number inside the range.
By their numbers in this assay, from the lowest: compound 1; then compounds 3 and 2 (each within the scatter of the next).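

In this assay, exchanging the whole 4-carboxy-1-(methoxymethyl)cyclohexyl group on the carbonyl carbon for 1,1-dioxothian-4-yl gives a number 7 percentage points lower from compound 2 to compound 3 (within the scatter), so among the compounds shown, a high amount remaining at this position does not require the carboxy-bearing cyclohexyl group, and a group with no hydrogen-bond donor also reaches it. The exchange from the methoxy-bearing group gives a number 11 percentage points higher from compound 1 to compound 3 (beyond the scatter), which places the entering sulfur-containing ring with the methoxymethyl group of compound 2 rather than with the methoxy group of compound 1 in this assay. Nothing at hand explains why the read-out holds across so large a change in the group on the carbonyl carbon.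

As far as these compounds go, it remains open whether an amine in place of the carboxylic acid on the cyclohexyl ring, or a longer chain in place of the methoxymethyl group, would keep the amount remaining this high. Compound 2 gives 100% in this assay, the full amount remaining, so any gain from a further change at this position could not be read against it.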